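Methyl on the ring nitrogen of a dichlorophenyl indole

The source may report more compounds than this note shows. Statements on the series, on what has been measured and on what is new or still open speak of the compounds shown alone.

Compounds with a value so far:
compound 1, `Cn1c(-c2ccc(Cl)c(Cl)c2)cc2ccccc21`, gives 20%
compound 2, `Nc1ccc2[nH]c(-c3ccc(Cl)c(Cl)c3)cc2c1`, gives 21.4%

In an assay on isolated protein for inhibition of Aromatase (Homo sapiens), read by fluorescence, using NADPH, with a stated time of 30 min, tested at 50 uM (a lower number here means less inhibition, a higher number more inhibition at the concentration tested (going by the name of the read-out)), compound 2 gives 21.4%, and compound 1 gives 20%; the gap between these two numbers lies within the scatter, so the two compounds cannot be told apart on this evidence. Compound 3, `Cn1c(-c2ccc(Cl)c(Cl)c2)cc2cc(N)ccc21`, has not been measured. It differs from compound 2 in one place: methyl in place of hydrogen on an aromatic nitrogen. Within the data shown here, no step between two measured compounds is available to show what this change does. Both measured compounds sit in the same low band, so the change from compound 2 to compound 3 is expected to bring no step beyond the scatter, in either direction: a number 0.4 percentage points lower from compound 2 to compound 3 (within the scatter). Compound 3 is therefore estimated at 21%, with a range from 6% to 38%.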

Compound 3, a percentage reported as inhibition, at one concentration (the size of the read-out at that concentration, not a potency): 42%
Compound 3: middle estimate off by 21 percentage points, on the low side, outside the stated range (above it).
By their numbers in this assay, from the lowest: compounds 1 and 2 (each within the scatter of the next); then compound 3.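

With the amino group in place, methyl in place of hydrogen on the aromatic nitrogen gives a number 20.6 percentage points higher from compound 2 to compound 3 (beyond the scatter) in this assay, so this ring nitrogen is a position where one added carbon moves the number beyond the scatter. With the methyl in place, amino in place of hydrogen on an aromatic carbon gives a number 22 percentage points higher from compound 1 to compound 3 (beyond the scatter) in the same assay, a second step beyond the scatter that compounds 1 and 2, which differ from each other in two places, could not reveal. Nothing available here explains either step.

On these data alone, whether an ethyl group or a longer chain on the ring nitrogen would go further remains open. So does whether a hydroxyl or an amide could stand in for the amino group on that aromatic carbon.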